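Swapping the aryl group on a chalcone-like chain

A few compounds are considered here, and "the series" means these few. Any claim that something is new, unique, unknown or untested is made for them only; others in the source may bear on it.

Measured compounds:
Compound 1, `COc1cc(OC)c(OC)cc1/C=C/C(=O)c1ccc(OC)c2c1OC(C)(C)C=C2`, in a functional assay on HT-29 cells (Homo sapiens) for antiproliferative activity, read by MTT assay, with a stated time of 24 h (on this read-out lower numbers stand for stronger inhibition and higher numbers for weaker inhibition), gives > 10000 nM, a limit of the assay.
Compound 2, `COc1ccc(C(=O)/C=C/c2cccc(F)c2)c2c1C=CC(C)(C)O2`, in this assay gives > 10000 nM, also a limit of the assay.
Compound 3, `COc1ccc(C(=O)/C=C/c2ccc(N(c3ccccc3)c3ccccc3)cc2)c2c1C=CC(C)(C)O2`, in this assay gives > 10000 nM, again a limit of the assay.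

None of the three compounds gives a real number in this assay; every value is a limit, so compound 2 stands exactly where compound 1 and compound 3 stand, at the edge of what the assay can report. Going by the values given here, no step between measured compounds can be given, since each pair only shows two limits, and the single line of support is the limit of > 10000 nM in this assay, at which 3 of the 3 values shown sit.

The unmeasured compound 4, `COc1ccc(C(=O)/C=C/c2cccs2)c2c1C=CC(C)(C)O2`, differs from compound 2 in one place: thiophen-2-yl in place of 3-fluorophenyl on a double-bonded chain carbon bound to a double-bonded chain carbon. Among the compounds with values here, with three limits and no measured step, the change from compound 2 to compound 4 is expected to produce no movement beyond the scatter, and compound 4 is most likely to return a limit as well.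

For compound 4 in this assay, the expected step is a step that the limit leaves unreadable from compound 2 to compound 4. Compound 4 is estimated at 15000 nM, within a range from 4000 nM to 60000 nM.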

Compound 4, half-maximal inhibitory concentration: > 10000 nM
Compound 4 gave a limit, no number; the forecaster's own chance of this, stated with the estimate: 80%; the middle value is on the limit's open side.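

Going by these compounds alone, no step from compound 2 to compound 4 can be read, since both give only a limit in this assay and no number: the limit of > 10000 nM in this assay, at which 4 of the 4 values shown sit. The compounds shown leave open which group on this chain, if any, would give a real number in this assay.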